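Formyl replacing methoxy on the aryloxy imidazoline core

A few compounds are considered here, and "the series" means these few. Any claim that something is new, unique, unknown or untested is made for them only; others in the source may bear on it.

Measured so far:
compound 1, `CC(Oc1ccccc1Br)C1=NCCN1`, 10 nM
compound 2, `COc1ccccc1OC(C)C1=NCCN1`, 9770 nM

In a functional assay on CHO cells for agonist activity at Alpha-2C adrenergic receptor (Homo sapiens) (a lower number here means that less compound is needed, a higher number that more compound is needed for the effect), compound 1 gives 10 nM, while compound 2 gives 9770 nM, the highest of the two numbers; its nearest neighbour is compound 1, separated by the step of a 980-fold higher number from compound 1 to compound 2 (2.99 log units; beyond the scatter), in which methoxy replaced bromo on an aromatic carbon. Compound 3, `CC(Oc1ccccc1C=O)C1=NCCN1`, has not yet been measured. It differs from compound 2 by formyl in place of methoxy on an aromatic carbon. Among the measured compounds shown here, only the step from compound 1 to compound 2 bears on this change, and it shows that what stands at this aromatic carbon can move the number very far in this assay. Formyl is neither bromo nor methoxy, so the direction is uncertain, but a sizeable change is expected. Compound 3 is estimated at 1000 nM, within 100 nM to 10000 nM, an expected step of a 9.8-fold lower number from compound 2 to compound 3 (0.99 log units; beyond the scatter).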

Compound 3, half-maximal effective concentration: 100 nM
For compound 3 the middle estimate is 10-fold (1.00 log units) above the measured one; the measured number falls inside the stated range.
By their numbers in this assay, from the lowest: compound 1; then compound 3; then compound 2.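

In this assay formyl takes back much of what methoxy cost at this aromatic carbon, as the change shows a 98-fold lower number from compound 2 to compound 3 (1.99 log units; beyond the scatter) in the number. Formyl does not reach bromo, though, with a 10-fold higher number from compound 1 to compound 3 (1.00 log units; beyond the scatter) on that swap, so all three groups at this carbon are now set apart beyond the scatter. Methoxy and formyl also count the same heavy atoms and hydrogen-bond acceptors, so these counts alone do not set the number here, and nothing available explains the gap between the two groups.

The compounds shown leave open where other groups, such as an amine, a carboxylic acid or a longer alkoxy chain, would fall relative to bromo and formyl at this carbon. They also cannot tell whether the same order of groups would hold on any other version of the shared core.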